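The source may hold more compounds than are shown below. What is called first, only, known or untested is meant among the compounds shown, and "the series" means these compounds.

Compound 3 `N#CC1=C(NC(=S)Nc2ccc(Cl)cc2)N(c2ccc(S(N)(=O)=O)cc2)C2=C(C(=O)CCC2)C1c1ccc(Cl)cc1Cl` gives the highest of the three numbers in a functional assay on Ehrlich cells (Mus musculus) for cytotoxicity, read by trypan blue exclusion, with a stated time of 2 h, tested at 100 ug/mL (a higher number here means a stronger effect of the compound at the concentration tested, a lower number a weaker effect), at 100%. Compound 1 `N#CC1=C(N)N(c2ccc(S(N)(=O)=O)cc2)C2=C(C(=O)CCC2)C1c1ccc(Cl)cc1Cl` gives 95%, and compound 2 `CCCCNC(=S)NC1=C(C#N)C(c2ccc(Cl)cc2Cl)C2=C(CCCC2=O)N1c1ccc(S(N)(=O)=O)cc1` gives 40%. Compound 4 `N#CC1=C(NC(N)=O)N(c2ccc(S(N)(=O)=O)cc2)C2=C(C(=O)CCC2)C1c1ccc(Cl)cc1Cl` differs from compound 3 in one place: a group of 3 heavy atoms (1 carbon, 1 nitrogen, 1 oxygen; no ring) in place of a group of 10 heavy atoms (7 carbon, 1 nitrogen, 1 sulfur, 1 chlorine; one six-membered aromatic ring of carbon only), on an amine nitrogen. Going by the values given here, no measured step involves a carbamoyl, so any comparison is indirect. Putting a large group on the amine nitrogen changed little, a number 5 percentage points higher from compound 1 to compound 3 (within the scatter), whereas the butyl-bearing analogue fell a long way, a number 55 percentage points lower from compound 1 to compound 2 (beyond the scatter), and a number 60 percentage points higher from compound 2 to compound 3 (beyond the scatter) undid that loss. A small group on this nitrogen may therefore land anywhere between these outcomes, and compound 4 is expected to give a somewhat lower number, a number 20 percentage points lower from compound 3 to compound 4 (beyond the scatter), with wide uncertainty. The estimate for compound 4 is 80%, between 45% and 100%.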

Compound 4, a percentage reported as activity, at one concentration (the size of the read-out at that concentration, not a potency): 60%
For compound 4 the middle estimate is 20 percentage points above the measured one, and the stated range covers the measured number.
By their numbers in this assay, from the lowest: compound 2; then compound 4; then compounds 1 and 3 (each within the scatter of the next).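

With carbamoyl on the amine nitrogen, the number in this assay falls well short of that of the free amine (a number 35 percentage points lower from compound 1 to compound 4 (beyond the scatter)) and of the group bearing 4-chlorophenyl (a number 40 percentage points lower from compound 3 to compound 4 (beyond the scatter)), yet stays above the group bearing butyl (a number 20 percentage points higher from compound 2 to compound 4 (beyond the scatter)). The count of heavy atoms therefore does not order these results: the largest group stays level with hydrogen, the smallest group lands in the middle, and the mid-sized group gives the lowest number. No measurement here explains this order. On these data alone, what an acetyl group or a plain phenyl would give on this nitrogen remains open.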